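The source may hold more compounds than are shown below. What is called first, only, known or untested is meant among the compounds shown, and "the series" means these compounds.

Measured compounds:
Compound 1, `O=C1C=C(N2CCC2)C(=O)c2c1nc1n2[C@H]2OC[C@@H](O)[C@H]2OC1` — in a functional assay on ECa-109 cells for inhibition, with ECa-109 cell line (Homo sapiens) as the target, read by sulforhodamine B assay (on this read-out higher numbers stand for weaker inhibition and lower numbers for stronger inhibition), compound 1 gives only a limit, > 16000 nM.
Compound 2, `O=C1C(Nc2ccc(Br)cc2)=CC(=O)c2c1nc1n2[C@H]2OC[C@@H](O)[C@H]2OC1` — compound 2 gives 1980 nM.
Compound 3, `O=C1C(N2CCCC2)=CC(=O)c2c1nc1n2[C@H]2OC[C@@H](O)[C@H]2OC1` — compound 3 gives only a limit, > 16000 nM.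

Compound 1 stands at the limit of > 16000 nM in this assay, at which 2 of the 3 values shown sit, so no number fixes where it lies; only the limit is known. Compound 4, `O=C1C=C(Nc2ccccc2)C(=O)c2c1nc1n2[C@H]2OC[C@@H](O)[C@H]2OC1`, differs from compound 1 by anilino in place of azetidin-1-yl on a double-bonded ring carbon. Within the data shown here, one measured step bears on this kind of change: an at least 8.0-fold higher number from compound 2 to compound 3 (0.90 log units; beyond the scatter), in which pyrrolidin-1-yl took the place of (4-bromophenyl)amino and the number rose at least modestly. The change from compound 1 to compound 4 runs the other way, from azetidin-1-yl to anilino, so a lower number, meaning stronger inhibition, is expected, toward what compound 2 shows with 1980 nM. Compound 4 is therefore expected to come in near 3500 nM, between 1000 nM and 16000 nM. That estimate means a step of an at least 4.5-fold lower number from compound 1 to compound 4 (0.66 log units; beyond the scatter).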

Compound 4, half-maximal inhibitory concentration: 4970 nM
For compound 4 the middle estimate is 1.4-fold (0.15 log units) below the measured one; the range from low to high includes it.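

In this assay, anilino in place of azetidin-1-yl on a double-bonded ring carbon gives an at least 3.2-fold lower number from compound 1 to compound 4 (0.50 log units; beyond the scatter). The earlier step involved (4-bromophenyl)amino, whereas this one shows that an anilino group without bromine can also give a lower number than a non-aromatic ring amine, at this ring carbon. The full size of the step stays unknown because compound 1 gives only a limit: the limit of > 16000 nM in this assay, at which 2 of the 4 values shown sit.

The change adds both an aromatic ring and a hydrogen-bond donor, so the compounds shown leave open which of the two matters. Cyclohexylamino, which keeps the nitrogen hydrogen without the aromatic ring, and N-methylanilino, which keeps the aromatic ring without that hydrogen, would help to separate the two at this ring carbon.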